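Chloro removal on the shared core: antiproliferative notes

The source may report more compounds than this note shows. Statements on the series, on what has been measured and on what is new or still open speak of the compounds shown alone.

Compound 1 `CCc1c(C)[nH]c2cc(OCCOc3ccccc3)c(Cl)cc2c1=O` is the reference point of this short series. In an ADME assay on J774 cells (Mus musculus) for antiproliferative activity, with a stated time of 72 h (a higher number here means that more compound is needed for the effect, a lower number that less compound is needed), compound 1 gives > 28000 nM, which is a limit of the assay and not a number. Compound 1 thus stands at the limit of > 28000 nM in this assay, at which 1 of the 2 values shown sits, and no single figure places it against any other entry. Compound 2 `CCc1c(C)[nH]c2cc(OCCCO)c(Cl)cc2c1=O` is the second measured member; in this assay compound 2 gives "not determined" (no result reported), so it adds nothing to the comparison. Compound 3 `CCc1c(C)[nH]c2cc(OCCOc3ccccc3)ccc2c1=O` is the unmeasured analogue and differs from compound 1 by hydrogen in place of chloro on an aromatic carbon. Within the data shown here, no step between measured compounds is available to size this change, and compound 1 itself is known only to a limit. The expected step is a step that the limit leaves unreadable from compound 1 to compound 3, none beyond the scatter. Compound 3 is therefore estimated to give 40000 nM in this assay, in the range 15000 nM to 120000 nM, and most likely again reported only as a limit.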

Compound 3, half-maximal effective concentration: 4000 nM
The estimate for compound 3 lay 10-fold (1.00 log units) above the measured number; the whole stated range lies above it.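

In this assay, among these compounds, hydrogen in place of chloro on this aromatic carbon, ortho to a large group, gives an at least 7.0-fold lower number from compound 1 to compound 3 (0.84 log units; beyond the scatter), the first readable change. Chloro is the only difference between the two compounds, so this position is not neutral for the read-out, and compound 3 gives the first single figure, 4000 nM. The true size of the step stays unknown because compound 1 is known only to a limit: the limit of > 28000 nM in this assay, at which 1 of the 3 values shown sits.

Going by these compounds, whether fluoro, methoxy or an amine on the same carbon would track with chloro or with hydrogen remains open. Also open, on these data alone, is whether the step carries over when a carboxylic acid or a longer chain replaces the side chain on the shared core.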